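This account rests on a few compounds, and the source may have more. Where it says the series, first, only, none or still open, it means among the compounds named here.

The series is followed in a physicochemical assay for acid dissociation. Compound 1 `COc1ccc(F)cc1CNCCCNc1ccnc2cc(CCc3ccccc3)ccc12` gives 9.47 in this assay. Compound 2 `COc1ccc(-c2ccc3c(NCCCNCc4cccc(OC)c4O)ccnc3c2)cc1` gives 9.47, level with compound 1 at the digits recorded, so the two stand together within the usual scatter. Going by the values given here, no step between compounds that differ in a single place has been measured so far.

Compound 3 `COc1cccc(CNCCCNc2ccnc3cc(CCc4ccccc4)ccc23)c1O` is the next compound for this assay. It differs from compound 2 in one place: phenethyl in place of 4-methoxyphenyl on an aromatic carbon. The same phenethyl group already sits on the core of compound 1, and compound 1 and compound 2 stand together in this assay, which gives no sign that this part of the molecule shifts the read-out. The expected step from compound 2 to compound 3 is therefore no change at the digits printed from compound 2 to compound 3 (within the scatter), nothing beyond the scatter in either direction. Compound 3 is estimated at 9.47, with a range from 9.2 to 9.75.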

Compound 3, acid dissociation constant: 9.47
Compound 3: middle estimate and measured number agree at the digits printed; low and high end bracket the measured number.
By their numbers in this assay, from the lowest: compounds 1, 2 and 3 (each within the scatter of the next).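

In this assay, going by these compounds alone, phenethyl in place of 4-methoxyphenyl on the aromatic carbon of the shared core gives no change at the digits printed from compound 2 to compound 3 (within the scatter), the first reading of a change made at this position alone. The other single-place change, 2-hydroxy-3-methoxyphenyl in place of 5-fluoro-2-methoxyphenyl on the saturated chain carbon bound to an amine nitrogen, gives no change at the digits printed from compound 1 to compound 3 (within the scatter), so neither exchange moves the read-out beyond the scatter. Nothing available explains either result.

The compounds shown leave open how the read-out responds when an amine or a carboxylic acid stands on that aromatic carbon. They also leave open whether a pyridyl ring on the saturated chain carbon, in place of the substituted phenyl groups, would shift it.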